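Chlorinated Acid End in Place of the Inactive Acid

The source may report more compounds than this note shows. Statements on the series, on what has been measured and on what is new or still open speak of the compounds shown alone.

The compounds here share one core: a ketone bearing a cyclopentyl group, joined through a flexible diether linker to an aromatic acid. Compound 3 `Cc1c(OCCCCOc2cccc(C(=O)O)c2)ccc(C(=O)CC2CCCC2)c1C` carries a 3-carboxyphenyl at the far end, and in an assay on HEK293 cells for positive allosteric modulation of metabotropic glutamate receptor 2 (Rattus norvegicus), read by thallium flux, with a stated time of 2.5 min (on this read-out lower numbers stand for an effect already at smaller amounts and higher numbers for an effect only at larger amounts of compound), compound 3 is reported as "not active" (no number reported), so no number stands for it. Compound 1 `Cc1c(OCCCCOc2ccc(C(=O)O)cc2)ccc(C(=O)CC2CCCC2)c1C` is reported as "not determined" (no result reported) in this assay. Compound 2 `Cc1c(OCCCCOc2ccc(C(=O)O)c(Cl)c2)ccc(C(=O)CC2CCCC2)c1O`, which bears a 4-carboxy-3-chlorophenyl and also differs in its core, gives 510 nM in this assay. Compound 4 `Cc1c(OCCCCOc2ccc(C(=O)O)c(Cl)c2)ccc(C(=O)CC2CCCC2)c1C` has not been measured; the change from compound 3 is 4-carboxy-3-chlorophenyl in place of 3-carboxyphenyl on an oxygen on a saturated carbon. Going by the values given here, no pair of measured compounds differs by just this change, so the size of the step is open. Since compound 3 gave no number, the step cannot be stated as a ratio; the expectation is that compound 4 moves from no measurable effect to a measurable one. Compound 4 is estimated at 700 nM, with a likely range from 150 nM to 4000 nM. This rests on compound 2, which carries the same acid end and gives 510 nM.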

Compound 4, half-maximal effective concentration: 2420 nM
Compound 4: middle estimate off by 3.5-fold (0.54 log units), on the low side; low and high end bracket the measured number.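

In this assay compound 4 gives a real number with the 4-carboxy-3-chlorophenyl end, where compound 3 with the 3-carboxyphenyl end gives none, so the steps from compound 3 and compound 1 cannot be read. With that acid end kept, methyl in place of hydroxy on an aromatic carbon gives a 4.7-fold higher number from compound 2 to compound 4 (0.68 log units; beyond the scatter) and so shows that the core also weighs on the result, with the hydroxy form acting at smaller amounts. Nothing at hand explains either of these differences.

The chlorine and the shifted acid change together between compound 3 and compound 4, and compound 1, which lacks the chlorine, gives no result that could separate them. As far as these compounds go, how a bromine or a fluorine in place of the chlorine, or an amide in place of the carboxylic acid, would read remains open.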